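Methyl gives way to chloro in compound 3

The compounds below may be only part of what the source reports. "The series", "measured", "known", "first", "only" and "open" are said of these compounds alone.

Compound 1 `Oc1ccccc1NC(=S)Nc1ccc2[nH]ccc2c1`: 509000 nM
Compound 2 `Cc1ccc(NC(=S)Nc2ccc3[nH]ccc3c2)c(O)c1`: 370000 nM

In an ADME assay on CHO-K1 cells (Cricetulus griseus) for cytotoxicity, read by MTT assay, with a stated time of 24 h (a lower number here means that less compound is tolerated, a higher number that more compound is tolerated), compound 2 cannot be told apart from compound 1. Among the compounds with values here, the only measured step is a 1.4-fold lower number from compound 1 to compound 2 (0.14 log units; within the scatter), and it came from adding methyl in place of hydrogen on an aromatic carbon. Compound 3 `Oc1cc(Cl)ccc1NC(=S)Nc1ccc2[nH]ccc2c1` carries chloro in place of methyl on an aromatic carbon, on that same carbon (chloro in place of methyl on an aromatic carbon). Within the data shown here, no chloro compound has been measured, so this single small step is the only guide, and no change beyond the scatter is expected. The expected step is a 1.1-fold lower number from compound 2 to compound 3 (0.05 log units; within the scatter). For compound 3 the estimated value is 330000 nM, with an expected range of 150000 nM to 650000 nM.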

Compound 3, concentration lethal to 50% of the cells: 251000 nM
Beside the measured number, compound 3's estimate is 1.3-fold (0.12 log units) above it, and the stated range covers the measured number.
By their numbers in this assay, from the lowest: compounds 3, 2 and 1 (each within the scatter of the next, the first and the last beyond it).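

Chloro in place of methyl gives a 1.5-fold lower number from compound 2 to compound 3 (0.17 log units; within the scatter) in this assay and so cannot be told apart from methyl on this carbon. Chloro in place of hydrogen on the same carbon gives a 2.0-fold lower number from compound 1 to compound 3 (0.31 log units; beyond the scatter) and is the first step here to pass the scatter, though only modestly. No measurement at hand offers a reason for this small shift.

From the compounds shown here alone, whether an amine or a carboxylic acid on this carbon would give a larger step remains open. So does whether chloro on another carbon of this ring would give a similar step.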